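Compound 3: a new group on the sulfonyl sulfur

The source may report more compounds than this note shows. Statements on the series, on what has been measured and on what is new or still open speak of the compounds shown alone.

In an ADME assay on HEK293 cells (Homo sapiens) for cytotoxicity, read by resazurin assay, with a stated time of 48 h (on this read-out lower numbers stand for higher toxicity in this test and higher numbers for lower toxicity in this test), compound 1 `O=S(=O)(Nc1ccc(-c2nc3ccccc3o2)cc1)c1ccccc1O` gives > 100000 nM as a limit of the assay and not a number. Compound 2 `COc1ccc(S(=O)(=O)Nc2ccc(-c3nc4ccccc4o3)cc2)cc1` gives > 100000 nM as a limit too. Within the data shown here, compound 2 thus has no number of its own, and the only evidence on where it stands is the limit of > 100000 nM in this assay, at which 2 of the 2 values shown sit, with nothing measured on the scale itself. Among the measured compounds shown here, the one measured step that bears on the change is a step that the two limits leave unreadable from compound 1 to compound 2 with 4-methoxyphenyl in place of 2-hydroxyphenyl on a sulfonyl sulfur, and it offers no size to carry forward. Compound 3 `COc1ccc(Cl)cc1S(=O)(=O)Nc1ccc(-c2nc3ccccc3o2)cc1` carries 5-chloro-2-methoxyphenyl in place of 4-methoxyphenyl on a sulfonyl sulfur with the rest of compound 2 unchanged. The expectation rests on compound 2 and its limit of > 100000 nM as the only starting point. No change beyond the scatter is expected, so the estimated step is a number no higher from compound 2 to compound 3 (the limit leaves the size open) in this assay and any readable shift is expected toward higher toxicity. Compound 3 is estimated at 100000 nM with an expected range from 35000 nM to 200000 nM.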

Compound 3, half-maximal cytotoxic concentration: 75000 nM
Estimate against measurement, compound 3: 1.3-fold (0.12 log units) above; the range from low to high includes it.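

In this assay, compound 3 is the first compound shown to give a number on the scale and not a limit, so a group on the sulfonyl sulfur, here 5-chloro-2-methoxyphenyl, can now be tied to a readable value. As far as these compounds go, measured against the two earlier compounds, the change reads as an at least 1.3-fold lower number from compound 2 to compound 3 (0.12 log units; that floor lies within the scatter), and as an at least 1.3-fold lower number from compound 1 to compound 3 (0.12 log units; that floor lies within the scatter); each of these is only a floor, so the true size remains open and may or may not exceed the scatter. The step between the two earlier compounds still cannot be read, and the comparison has only limits to start from: the limit of > 100000 nM in this assay, at which 2 of the 3 values shown sit.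

The compounds shown leave open whether the chloro or the methoxy part of 5-chloro-2-methoxyphenyl goes with the readable value, as the change brings them in together and compound 2 already carries a methoxy group elsewhere on its ring. They also leave open how an amine or a carboxylic acid on that ring, or a bromine in place of the chlorine, would read in this assay.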